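Cap replacement on the hydroxamate series: compound 1 to compound 4

This account rests on a few compounds, and the source may have more. Where it says the series, first, only, none or still open, it means among the compounds named here.

Compound 1 `CN(C)c1ccc(C(=O)N[C@@H](CCCCCC(=O)NO)C(=O)NCc2ccccc2)cc1` is the anchor of this step. Among the measured compounds shown here, in a functional assay on NFF cells (Homo sapiens) for antiproliferative activity (on this read-out lower numbers stand for stronger inhibition and higher numbers for weaker inhibition), compound 1 gives 12000 nM, the highest of the three numbers measured so far. Compound 3 `O=C(CCCCCC(NC(=O)c1ccc([N+](=O)[O-])cc1)C(=O)NCc1ccccc1)NO` gives 9000 nM, within the scatter of compound 1, while compound 2 `CN(C)c1ccc(C(=O)NC(CCCCCC(=O)NO)C(=O)NCc2ccccc2)cc1` gives 870 nM. The two measured steps are both large: a 14-fold lower number from compound 1 to compound 2 (1.14 log units; beyond the scatter), and a 10-fold higher number from compound 2 to compound 3 (1.01 log units; beyond the scatter). The first of these turns only on the fact that one of compounds 1 and 2 is drawn with a defined configuration and the other without, at the place where they differ and does not touch the cap; the second changes a substituent on the aromatic cap but keeps the ring. Compound 4 `O=C(/C=C/c1c[nH]c2ccccc12)N[C@@H](CCCCCC(=O)NO)C(=O)NCc1ccccc1` is not yet measured. It differs from compound 1 as follows: 2-(1H-indol-3-yl)ethenyl in place of 4-(dimethylamino)phenyl on a carbonyl carbon. For the measured compounds named here, no measured step replaces the whole cap in this way, so the measured steps give no direction for the change. The expectation is therefore a number near that of compound 1, with a 2.0-fold lower number from compound 1 to compound 4 (0.30 log units; within the scatter) expected to stay close to the scatter, and a wide range owing to the lack of any comparable step. Compound 4 is estimated at 6000 nM, expected between 1500 nM and 25000 nM.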

Compound 4, half-maximal inhibitory concentration: 10400 nM
Estimate against measurement, compound 4: 1.7-fold (0.24 log units) below, within the range that was stated.
By their numbers in this assay, from the lowest: compound 2; then compounds 3, 4 and 1 (each within the scatter of the next).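

In this assay, replacing the whole cap on the carbonyl carbon gives a 1.2-fold lower number from compound 1 to compound 4 (0.06 log units; within the scatter), so with the stereocentre drawn S this assay does not separate 4-(dimethylamino)phenyl from 2-(1H-indol-3-yl)ethenyl. The earlier cap change, a 10-fold higher number from compound 2 to compound 3 (1.01 log units; beyond the scatter), was read only on compounds drawn without a configuration and kept the ring, whereas this one brings in a different ring system, a double bond outside the aromatic rings and a hydrogen-bond donor, and still stays within the scatter. Among the compounds shown here, the only step from compound 1 beyond the scatter remains the one that does not touch the cap, and it rests on this: the fact that one of compounds 1 and 2 is drawn with a defined configuration and the other without, at the place where they differ.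

From the compounds shown here alone, whether the indole cap would also match the 4-(dimethylamino)phenyl cap without a drawn configuration stays open. The compounds shown also do not tell how a carboxylic acid in place of the dimethylamino group would read with the S drawing.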